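The source may report more compounds than this note shows. Statements on the series, on what has been measured and on what is new or still open speak of the compounds shown alone.

Measured in a functional assay on HeLa cells (Homo sapiens) for antiproliferative activity, read by CCK-8 assay, with a stated time of 72 h; on this read-out higher numbers stand for weaker inhibition and lower numbers for stronger inhibition:
- compound 1 `COc1cc(-c2ncncc2-c2ccc(SC)cc2)cc(OC)c1OC`: 220 nM
- compound 2 `CCOc1ccc(-c2cncnc2-c2cc(OC)c(OC)c(OC)c2)cc1Cl`: 90 nM
- compound 3 `CCOc1ccc(-c2cncnc2-c2cc(OC)c(OC)c(OC)c2)cc1C(F)(F)F`: 790 nM

Compound 1 takes the middle place among these three numbers, with compound 2 lower and compound 3 higher. Compound 4 `COc1cc(-c2ncncc2-c2ccc(C(N)=O)cc2)cc(OC)c1OC` has not been measured yet. It keeps the core of compound 1 and differs in one group: carbamoyl in place of methylsulfanyl on an aromatic carbon. This is carbamoyl in place of methylsulfanyl on an aromatic carbon, para to a large group.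

Among the measured compounds shown here, no measured step makes this same exchange. For the measured compounds named here, the only guide is an 8.8-fold higher number from compound 2 to compound 3 (0.94 log units; beyond the scatter), where trifluoromethyl takes the place of chloro on an aromatic carbon. That step shows that one exchanged group can move the number beyond the scatter, but it involves different groups, so it indicates a size more firmly than a direction. Going by the values given here, with only this upward step to go on, a rise of similar size is the cautious expectation.

The expected change is a 4.1-fold higher number from compound 1 to compound 4 (0.61 log units; beyond the scatter). For compound 4 the estimated value is 900 nM, with an expected range from 200 nM to 5000 nM.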

Compound 4, half-maximal inhibitory concentration: > 100000 nM
Compound 4 gave a limit, no number (the forecaster's own chance of this, stated with the estimate: 5%); middle value at least 110-fold (2.04 log units) from the limit.
By their numbers in this assay, from the lowest: compound 2; then compound 1; then compound 3. At a limit, above all of these: compound 4.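

Exchanging methylsulfanyl for carbamoyl on this aromatic carbon, para to a large group, gives an at least 450-fold higher number from compound 1 to compound 4 (2.65 log units; beyond the scatter) in this assay. Among the compounds shown here, one group at this place can therefore take a compound from a measurable number to the end of what the assay reports, and the only earlier step, an 8.8-fold higher number from compound 2 to compound 3 (0.94 log units; beyond the scatter), exchanged other groups and was clearly smaller. Compound 4 has a limit and not a number: the limit of > 100000 nM in this assay, at which 1 of the 4 values shown sits.

A single exchange cannot tell whether this loss is specific to carbamoyl or would follow from replacing methylsulfanyl with other groups, and these compounds do not reveal its cause. A nitrile, a carboxylic acid or a methoxy group at the same place would show how narrow the requirement there is.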